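From methyl to fluoro on the 4-methylphenyl group

This account rests on a few compounds, and the source may have more. Where it says the series, first, only, none or still open, it means among the compounds named here.

Compound 1 `CCCCS(=O)(=O)N1CCC2(CC1)OOC1(CCCCCC1)OO2`: > 100 ug/mL (a limit)
Compound 2 `O=S(=O)(Cc1ccccc1)N1CCC2(CC1)OOC1(CCCCCC1)OO2`: > 100 ug/mL (a limit)
Compound 3 `Cc1ccc(S(=O)(=O)N2CCC3(CC2)OOC2(CCCCCC2)OO3)cc1`: > 100 ug/mL (a limit)

In a functional assay on Huh-7 cells (Homo sapiens) for cytotoxicity, read by MTT assay, with a stated time of 72 h (a lower number here means that less compound is tolerated, a higher number that more compound is tolerated), compound 3 stands at > 100 ug/mL, which is a limit and not a number. The whole set rests at the limit of > 100 ug/mL in this assay, at which 3 of the 3 values shown sit. Compound 4 `O=S(=O)(c1ccc(F)cc1)N1CCC2(CC1)OOC1(CCCCCC1)OO2` carries fluoro in place of methyl on an aromatic carbon, para to a large group (fluoro in place of methyl on an aromatic carbon). The nearest measured changes are a step that the two limits leave unreadable from compound 1 to compound 3 and a step that the two limits leave unreadable from compound 2 to compound 3. Both altered the group on the sulfonyl sulfur, and neither has a readable size. No step beyond the scatter is therefore expected in this assay, in either direction. The expected outcome is a number no higher from compound 3 to compound 4 (the limit leaves the size open). For compound 4 the estimated value is 100 ug/mL, with an expected range of 50 ug/mL to 200 ug/mL.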

Compound 4, half-maximal cytotoxic concentration: > 100 ug/mL
Compound 4 ended at the assay's limit (the forecaster's own chance of this, stated with the estimate: 85%); the middle value lies on the limit itself.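

In this assay compound 4 gives > 100 ug/mL as a limit and not a number, so its steps from compound 1, compound 2 and compound 3 cannot be read. The compounds shown leave open where any of the four would fall beyond that limit, and whether the group on the sulfonyl sulfur matters here at all.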